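The compounds below may be only part of what the source reports. "The series", "measured", "known", "first", "only" and "open" are said of these compounds alone.

Measured compounds, with their values in a functional assay, with a stated time of 20 min; a higher number here means a weaker inhibitor, a lower number a stronger inhibitor:

Compound 1, `CCOC(=O)c1cnn(-c2nc(-c3ccc(Cl)cc3)c(C#N)c(=O)n2C)c1N`: 64 ug/mL
Compound 2, `CCOC(=O)c1cnn(-c2nc(-c3ccccc3F)c(C#N)c(=O)n2C)c1N`: 69 ug/mL
Compound 3, `CCOC(=O)c1cnn(-c2nc(-c3cccc(O)c3O)c(C#N)c(=O)n2C)c1N`: 41 ug/mL

Compound 3 gives the lowest of the three numbers, but its separation from the others is small: a 1.6-fold lower number from compound 1 to compound 3 (0.19 log units; within the scatter) and a 1.7-fold lower number from compound 2 to compound 3 (0.23 log units; within the scatter) are both within the scatter, as is a 1.1-fold higher number from compound 1 to compound 2 (0.03 log units; within the scatter). The three compounds therefore cannot be ranked in this assay; the shared core carries three different aryl groups on the same aromatic carbon and the read-out hardly moves.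

Compound 4, `CCOC(=O)c1cnn(-c2nc(-c3ccc(N(C)C)cc3)c(C#N)c(=O)n2C)c1N`, changes that same position once more: 4-(dimethylamino)phenyl in place of 2,3-dihydroxyphenyl on an aromatic carbon. All three measured steps bear on it, since each also swaps the aryl group at this carbon, and none of them left the scatter. Nothing in the series points to a larger response from a fourth aryl group, so in this assay compound 4 is expected to sit close to compound 3, with a 1.3-fold higher number from compound 3 to compound 4 (0.13 log units; within the scatter) expected to stay within the scatter. The estimate for compound 4 is 55 ug/mL, expected to fall between 25 ug/mL and 120 ug/mL.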

Compound 4, half-maximal inhibitory concentration: 98 ug/mL
For compound 4 the middle estimate is 1.8-fold (0.25 log units) below the measured one; low and high end bracket the measured number.
By their numbers in this assay, from the lowest: compounds 3, 1, 2 and 4 (each within the scatter of the next, the first and the last beyond it).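

In this assay this aryl position shows its first step beyond the scatter: a 2.4-fold higher number from compound 3 to compound 4 (0.38 log units; beyond the scatter), with 4-(dimethylamino)phenyl in place of 2,3-dihydroxyphenyl. The step is modest and isolated, as a 1.4-fold higher number from compound 2 to compound 4 (0.15 log units; within the scatter) and a 1.5-fold higher number from compound 1 to compound 4 (0.19 log units; within the scatter) both stay within the scatter, so compound 4 separates only from compound 3 and the position still gives a narrow range across four aryl groups. No measurement at hand accounts for this step.

The exchange removes both hydroxyl groups and brings in dimethylamino at once, so the compounds shown do not say which of the two changes carries the step. Still open, going by these compounds, is how this carbon responds to a phenyl ring bearing a single hydroxyl, a primary amine or a carboxylic acid.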